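This account rests on a few compounds, and the source may have more. Where it says the series, first, only, none or still open, it means among the compounds named here.

Of the compounds shown here, two from this series have been tested so far. Compound 1, `CO[C@@H]1CC=C2NN(c3cc4ccccc4[nH]3)C(=O)C[C@]2(c2ccccc2)O1`, gives 8670 nM in a functional assay on A549 cells (Homo sapiens) for inhibition, read by sulforhodamine B assay, with a stated time of 48 h; a higher number here means a weaker inhibitor, a lower number a stronger inhibitor. Compound 2, `CO[C@@H]1CC=C2NN(c3cncnc3)C(=O)C[C@]2(C)O1`, gives 4100 nM in this assay, the lower of the two numbers; compound 1 sits higher by a gap that is beyond the usual scatter, so compound 2 is the stronger of the pair, though the two structures differ in more than one place and the gap cannot be tied to any single change.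

The next compound, compound 3, `CO[C@@H]1CC=C2NN(c3cncnc3)C(=O)C[C@]2(c2ccccc2)O1`, is built from compound 2 by one change, phenyl in place of methyl on a saturated ring carbon. Within the data shown here, no measured pair shows this change on its own, so its effect is unknown. Among the measured compounds shown here, the only hint is that compound 1, which also carries phenyl at that carbon, gives the higher number, but it differs elsewhere too. On that basis, only a modest step, if any, is expected for a 1.3-fold higher number from compound 2 to compound 3 (0.13 log units; within the scatter), and compound 3 is estimated to give about 5500 nM, within a range of 2000 nM to 16000 nM.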

Compound 3, half-maximal inhibitory concentration: 5200 nM
Compound 3: the middle estimate sits 1.1-fold (0.02 log units) above what was measured, within the range that was stated.
By their numbers in this assay, from the lowest: compounds 2, 3 and 1 (each within the scatter of the next, the first and the last beyond it).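

On the saturated ring carbon next to the ring oxygen, phenyl in place of methyl gives a 1.3-fold higher number from compound 2 to compound 3 (0.10 log units; within the scatter) in this assay, so a group of six heavy atoms and one aromatic ring can stand where a single carbon stood without a readable shift in the number. Among these compounds, compound 3 also gives the first comparison at the amide-type nitrogen in a ring with everything else held the same: pyrimidin-5-yl in place of 1H-indol-2-yl gives a 1.7-fold lower number from compound 1 to compound 3 (0.22 log units; within the scatter) and likewise leaves no readable difference, so neither single change separates its pair in this assay. Nothing on hand offers an explanation for either result.

Going by these compounds, both changes so far involve only carbon or aromatic groups at these two places, so it remains open whether a longer chain such as n-butyl, or an amine or a carboxylic acid carried at the saturated ring carbon, would move the number beyond the scatter. Also open, on these data alone, is what 1H-indol-2-yl on the nitrogen does when methyl rather than phenyl sits on that carbon, which would show whether the two places act independently.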